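Taking the fluoro off compound 2

The compounds below may be only part of what the source reports. "The series", "measured", "known", "first", "only" and "open" are said of these compounds alone.

Compound 1 `CN1CCN(c2ccc3c(c2)oc(=O)n3C(=O)NCCCCc2ccccc2)C(=O)C1`: 20000 nM
Compound 2 `CN1CCC(c2cc3oc(=O)n(C(=O)NCCCCc4ccccc4)c3cc2F)CC1`: 70000 nM

In a physicochemical assay for solubility, read by HPLC, in phosphate buffer, measured as kinetic solubility, with a stated time of 1 h, at pH 7.4, tested at 250 uM (on this read-out lower numbers stand for lower solubility and higher numbers for higher solubility), compound 2 stands highest of the two, and its gap to compound 1 lies beyond the usual scatter. Compound 3 `CN1CCC(c2ccc3c(c2)oc(=O)n3C(=O)NCCCCc2ccccc2)CC1` differs from compound 2 in one place: hydrogen in place of fluoro on an aromatic carbon, ortho to a 1-methylpiperidin-4-yl group (hydrogen in place of fluoro on an aromatic carbon). For the measured compounds named here, no measured pair shows this change alone, so the expectation rests on compound 2 and its 70000 nM. The expected step is a 1.2-fold higher number from compound 2 to compound 3 (0.08 log units; within the scatter), none beyond the scatter. For compound 3 the estimated value is 85000 nM, with an expected range of 30000 nM to 200000 nM.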

Compound 3, solubility: 120000 nM
Estimate against measurement, compound 3: 1.4-fold (0.15 log units) below; the range from low to high includes it.
By their numbers in this assay, from the lowest: compound 1; then compounds 2 and 3 (each within the scatter of the next).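

In this assay, hydrogen in place of fluoro on this aromatic carbon, ortho to a 1-methylpiperidin-4-yl group, gives a 1.7-fold higher number from compound 2 to compound 3 (0.23 log units; within the scatter), so this change does not separate the two compounds. For the compounds shown here, with hydrogen on that carbon, 1-methylpiperidin-4-yl in place of 4-methyl-2-oxopiperazin-1-yl gives a 6.0-fold higher number from compound 1 to compound 3 (0.78 log units; beyond the scatter), the only new step beyond the scatter. No measurement at hand explains either step. As far as these compounds go, whether chloro or methoxy on this carbon would read the same remains open. So does how a morpholine ring in place of the 1-methylpiperidin-4-yl group would read.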